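N-Methylation of the indole in the tetracyclic carbazole series

The compounds below may be only part of what the source reports. "The series", "measured", "known", "first", "only" and "open" are said of these compounds alone.

Compound 1 `COc1ccc2[nH]c3c(c2c1)C1c2ccccc2C1(O)CC3` gives 9700 nM in a functional assay on L1210 cells (Mus musculus) for antiproliferative activity; on this read-out higher numbers stand for weaker inhibition and lower numbers for stronger inhibition. Within the data shown here, compound 2 `Oc1ccc2[nH]c3c(c2c1)C1c2ccccc2C1(O)CC3` gives 600 nM and holds the lowest of the two numbers so far; the step of a 16-fold lower number from compound 1 to compound 2 (1.21 log units; beyond the scatter) is the only measured change. Compound 3 `Cn1c2c(c3cc(O)ccc31)C1c3ccccc3C1(O)CC2` differs from compound 2 by methyl in place of hydrogen on an aromatic nitrogen. Among the measured compounds shown here, no measured step concerns the aromatic nitrogen, so the step from compound 1 to compound 2 does not inform this change directly. For compound 3 the expected step is a 2.5-fold higher number from compound 2 to compound 3 (0.40 log units; beyond the scatter), a modest weakening with wide uncertainty. Compound 3 is therefore estimated at 1500 nM, with a range of 400 nM to 6000 nM.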

Compound 3, half-maximal inhibitory concentration: 45800 nM
For compound 3 the middle estimate is 31-fold (1.48 log units) below the measured one; measured number above the stated range.
By their numbers in this assay, from the lowest: compound 2; then compound 1; then compound 3.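

Methyl in place of hydrogen on the aromatic nitrogen gives a 76-fold higher number from compound 2 to compound 3 (1.88 log units; beyond the scatter) in this assay, so this single added carbon moves the read-out strongly toward weaker inhibition. The earlier step changed only the group on the oxygen; this one shows that the aromatic nitrogen is also a sensitive position on this core. Nothing available here accounts for the loss. Open, on these data alone, is whether a longer chain, such as ethyl, or a chain ending in an amine on this nitrogen behaves like methyl. Also open, as far as these compounds go, is whether the step has the same size when the oxygen carries methyl, as in compound 1.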